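A few compounds are considered here, and "the series" means these few. Any claim that something is new, unique, unknown or untested is made for them only; others in the source may bear on it.

Measured compounds:
- compound 1 `COc1nc2ccc(Br)cc2cc1C(c1ccccc1)n1cc(-c2ccc(Br)cc2)nn1`: 7.43%
- compound 2 `CCCCCCCCc1cn(C(c2ccccc2)c2cc3cc(Br)ccc3nc2OC)nn1`: 2.27%
- compound 3 `CCCCCCc1cn(C(c2ccccc2)c2cc3cc(Br)ccc3nc2OC)nn1`: 2.32%

In an ADME assay on PC-3 cells (Homo sapiens) for cytotoxicity, read by sulforhodamine B assay, with a stated time of 48 h, tested at 10 uM (on this read-out higher numbers stand for more inhibition at the one concentration tested (going by the name of the read-out) and lower numbers for less inhibition), compound 3 stands second highest of the three numbers. Its nearest neighbour is compound 2, and the step of a number 0.1 percentage points higher from compound 2 to compound 3 (within the scatter) is within the scatter. The furthest is compound 1; both a number 5.2 percentage points lower from compound 1 to compound 2 (within the scatter) and a number 5.1 percentage points lower from compound 1 to compound 3 (within the scatter) are within the scatter as well, so the three numbers shown do not separate from one another.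

Compound 4 `COc1nc2ccc(Br)cc2cc1C(c1ccccc1)n1cc(CCCO)nn1` is not yet measured. It differs from compound 3 by hydroxy in place of propyl on a saturated chain carbon, three bonds along the chain from an aromatic carbon. Going by the values given here, the only measured step touching the same chain is a number 0.1 percentage points higher from compound 2 to compound 3 (within the scatter), which removed part of the chain and changed nothing beyond the scatter. Nothing measured introduces a hydroxy group, so the change in hydroxy in place of propyl on a saturated chain carbon, three bonds along the chain from an aromatic carbon is not covered by any step shown. With all three numbers low and close together, no step beyond the scatter in this assay is expected for compound 4.

The estimate for compound 4 in this assay is 3%, with a range from -4% to 10%. This estimate means a step of a number 0.7 percentage points higher from compound 3 to compound 4 (within the scatter), expected to remain within the scatter.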

Compound 4, a percentage reported as inhibition, at one concentration (the size of the read-out at that concentration, not a potency): 14.7%
Estimate against measurement, compound 4: 11.7 percentage points below; the whole stated range lies below it.
By their numbers in this assay, from the lowest: compounds 2, 3, 1 and 4 (each within the scatter of the next, the first and the last beyond it).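

In this assay, going by these compounds alone, hexyl to 3-hydroxypropyl is the first change at this position to pass the scatter (a step of a number 12.4 percentage points higher from compound 3 to compound 4 (beyond the scatter)), and octyl to 3-hydroxypropyl gives a step of the same size (a number 12.4 percentage points higher from compound 2 to compound 4 (beyond the scatter)), whereas trimming the alkyl chain from octyl to hexyl had changed nothing beyond the scatter. Against 4-bromophenyl, the 3-hydroxypropyl group does not separate (a number 7.3 percentage points higher from compound 1 to compound 4 (within the scatter)), so the position distinguishes the hydroxy chain from the two alkyl chains but not the aryl group from any of them. No measurement shown offers an explanation for these steps.

As far as these compounds go, whether the step belongs to the hydroxy group or to the shorter chain stays open, and a plain propyl chain, a 3-methoxypropyl chain, a 3-aminopropyl chain or a carboxylic acid at this place would bear on that. From the compounds shown here alone, all four numbers come from a single concentration in one cell line, so whether the step carries over to a potency also stays open.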